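The source may hold more compounds than are shown below. What is called first, only, known or untested is meant among the compounds shown, and "the series" means these compounds.

Compound 1 `COc1cc(CCc2ccc(Br)cc2)cc(OC)c1O` gives 1490 nM.
Compound 2 `COc1ccc(CCc2ccc([N+](=O)[O-])cc2)cc1OC` gives 13700 nM.
Compound 3 `COc1ccc(CCc2ccccc2Cl)cc1OC` gives 2040 nM.

These three numbers come from a functional assay on MKN-45 cells (Homo sapiens) for antiproliferative activity, read by MTT assay, with a stated time of 72 h; on this read-out lower numbers stand for stronger inhibition and higher numbers for weaker inhibition. Compound 1 has the lowest of the three numbers. Compound 3 sits within the usual scatter of compound 1, so the two cannot be told apart. Compound 2 lies clearly beyond the scatter, with a much higher number than compound 1.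

Compound 4 `COc1cc(CCc2ccc(Cl)cc2)cc(OC)c1O` has not yet been measured. It differs from compound 1 in one place: chloro in place of bromo on an aromatic carbon. Among the compounds with values here, no measured pair shows how this swap moves the number. The step from compound 1 to compound 4 is expected to stay within the scatter, with no firm direction, a 1.2-fold higher number from compound 1 to compound 4 (0.08 log units; within the scatter). Compound 4 is therefore estimated at 1800 nM in this assay, in a range from 800 nM to 4000 nM.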

Compound 4, half-maximal inhibitory concentration: > 25000 nM
Compound 4 ended at the assay's limit; the forecaster's own chance of this, stated with the estimate: 3%; at least 13-fold (1.14 log units) between middle value and limit.
By their numbers in this assay, from the lowest: compounds 1 and 3 (each within the scatter of the next); then compound 2. At a limit, above all of these: compound 4.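

The earlier compounds shown here offered no pair differing in one place, so they could not show how much this position matters. Here, on an aromatic carbon para to a large group, chloro in place of bromo gives an at least 16-fold higher number from compound 1 to compound 4 (1.22 log units; beyond the scatter), so exchanging one halogen for another is not a minor change on this core. In this assay compound 4 gives > 25000 nM, which is a limit and not a number: the limit of > 25000 nM in this assay, at which 1 of the 4 values shown sits.

As far as these compounds go, the full size of this step therefore stays open. So does what fluoro, iodo, a methyl group or an amine would give at this position.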